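A few compounds are considered here, and "the series" means these few. Any claim that something is new, unique, unknown or untested is made for them only; others in the source may bear on it.

Of the compounds shown here, two have been tested so far in a functional assay on the whole organism (strain Wistar) for inhibition, with Rattus norvegicus as the target, read by paw edema, with stated times of 30 min and 3 h, at a dose of 20 mg/kg; a higher number here means more inhibition at the dose given (going by the name of the read-out), a lower number less inhibition. Compound 1 `CCOC(=O)C1=C(C)NC(C)=C(C(=O)OCC)C1c1ccc(OCC(=O)Nc2ccc(C)cc2)cc1` gives 61.1%, and compound 2 `CCOC(=O)C1=C(C)NC(C)=C(C(=O)OCC)C1c1ccc(OCC(=O)NNC(=O)c2ccc(C)cc2)cc1` gives 47.3%, so compound 2 stands lowest of the two numbers. Going by the values given here, the one measured step, a number 13.8 percentage points lower from compound 1 to compound 2 (beyond the scatter), goes with ((4-methylphenyl)carbonyl)amino in place of 4-methylphenyl on an amide-type nitrogen. Compound 3 `CCOC(=O)C1=C(C)NC(C)=C(C(=O)OCC)C1c1ccc(OCC(=O)NNC(=O)c2ccccc2)cc1` differs from compound 2 in another part of the molecule: hydrogen in place of methyl on an aromatic carbon. Among the compounds with values here, no measured step bears directly on this change; the only step known concerns the amide-type nitrogen rather than the methyl on the aromatic ring, and a single methyl is a small piece of a large molecule. With nothing pointing either way, the step of a number 0.3 percentage points lower from compound 2 to compound 3 (within the scatter) is expected to stay within the scatter. Compound 3 is therefore estimated at 47%, with a range from 35% to 60%.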

Compound 3, a percentage reported as inhibition, in the whole organism at one dose (the size of the read-out at that dose, not a potency): 44.9%
Compound 3: the middle estimate sits 2.1 percentage points above what was measured; the range from low to high includes it.
By their numbers in this assay, from the lowest: compounds 3 and 2 (each within the scatter of the next); then compound 1.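

In this assay, hydrogen in place of methyl on this aromatic carbon gives a number 2.4 percentage points lower from compound 2 to compound 3 (within the scatter), so the methyl para to a large group can be removed with no change that stands out from the scatter. Benzamido in place of 4-methylphenyl on the amide-type nitrogen gives a number 16.2 percentage points lower from compound 1 to compound 3 (beyond the scatter), which shows that a drop beyond the scatter also appears when the benzoyl ring carries no methyl. Nothing measured here explains either result.

From the compounds shown here alone, compound 2 and compound 3 carry only methyl or hydrogen on this carbon, so it remains open whether chlorine, a methoxy group or an amine there would move the number beyond the scatter. Going by these compounds, it also remains open whether hydrogen in place of methyl on the ring of compound 1 would leave its number just as unchanged.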